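The source may report more compounds than this note shows. Statements on the series, on what has been measured and on what is new or still open speak of the compounds shown alone.

Of the compounds shown here, three have so far been tested in an ADME assay on cells (Peritoneal macrophage cell, Mus musculus) for cytotoxicity, read by fluorescence and resazurin assay, with a stated time of 3 days; a lower number here means that less compound is tolerated, a higher number that more compound is tolerated. Compound 1 `O=C(NCc1ccccc1)Nc1[nH]nc(-c2ccccn2)c1Cl` gives > 64000 nM, which is a limit of the assay and not a number. Compound 2 `COc1ccc(C(=O)Nc2[nH]nc(-c3ccccn3)c2C2CC2)cc1` gives > 64000 nM, which is also a limit. Compound 3 `N#Cc1ccc(C2CCN(C(=O)Nc3cc(-c4ccccn4)n[nH]3)CC2)cc1` gives > 64000 nM, again a limit. Within the data shown here, compound 3 therefore has no exact number to its name, and its place is shared by every compound tested so far: the limit of > 64000 nM in this assay, at which 3 of the 3 values shown sit.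

Compound 4 `O=C(Nc1cc(-c2ccccn2)n[nH]1)N1CCC(Oc2ccccc2)CC1` has not yet been measured. It differs from compound 3 in one place, with phenoxy in place of 4-cyanophenyl on a saturated ring carbon. The rest of the molecule stays the same.

Among the measured compounds shown here, no pair of tested compounds differs in only one place, so the effect of a single change cannot be read directly from these results. Even so, the three tested structures differ considerably from one another, and none has given an exact number. In this assay, no step beyond the usual scatter is expected in either direction. The estimated change is a number no higher from compound 3 to compound 4 (the limit leaves the size open). For compound 4, the expected value is 64000 nM. The estimated range for compound 4 runs from 30000 nM to 100000 nM.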

Compound 4, half-maximal cytotoxic concentration: > 40000 nM
Compound 4: no number, only a limit (the forecaster's own chance of this, stated with the estimate: 80%); the middle value does not contradict the limit.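

In this assay compound 4 gives > 40000 nM, a limit and not a number. Compound 3 gives > 64000 nM, also a limit, so the step to compound 4 cannot be read. The compounds shown leave open at what concentration any of them harms these cells, and whether phenoxy in place of 4-cyanophenyl changes that concentration at all.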